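Quinoline thioether series: working notes toward compound 3

The source may hold more compounds than are shown below. What is called first, only, known or untested is meant among the compounds shown, and "the series" means these compounds.

compound 1 `OCC#CCSc1cnc2ccccc2c1SCC#CCCl`: 3.3 ug/mL
compound 2 `O=C(/C=C/c1ccccc1)OCC#CCSc1cnc2ccccc2c1Cl`: 15.4 ug/mL

In a functional assay on CCRF-CEM cells (Homo sapiens) for antiproliferative activity, with a stated time of 72 h (on this read-out higher numbers stand for weaker inhibition and lower numbers for stronger inhibition), compound 1 gives 3.3 ug/mL, the lowest of the two numbers; compound 2 gives 15.4 ug/mL, higher; this gap lies beyond the scatter. Compound 3 `OCC#CCSc1cnc2ccccc2c1Cl` is not yet measured. It differs from compound 1 by one chlorine atom in place of a group of 6 heavy atoms (4 carbon, 1 sulfur, 1 chlorine; no ring), on an aromatic carbon; the group that leaves carries a triple bond outside aromatic rings and one hydrogen-bond acceptor. Compound 2, which also bears a chloro on the core, gives the higher number. Within the data shown here, no measured step covers this change, so the step of a 2.4-fold higher number from compound 1 to compound 3 (0.38 log units; beyond the scatter) is expected to be a moderate rise toward weaker inhibition. Compound 3 is estimated at 8 ug/mL, within 3 ug/mL to 20 ug/mL.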

Compound 3, concentration for 50% inhibition: 4.1 ug/mL
Estimate against measurement, compound 3: 2.0-fold (0.29 log units) above, within the range that was stated.
By their numbers in this assay, from the lowest: compounds 1 and 3 (each within the scatter of the next); then compound 2.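

In this assay, among these compounds, the step of a 1.2-fold higher number from compound 1 to compound 3 (0.09 log units; within the scatter) gives the first one-place comparison. At this aromatic carbon, opposite the ring nitrogen, the two numbers cannot be told apart when a chloro stands in place of the group of 6 heavy atoms, so that group with its triple bond is not needed to hold this level of inhibition. Nothing on hand accounts for this result.

Still open, on these data alone, is whether an amine or a methoxy group at this carbon would give a similar number. Also open, as far as these compounds go, is what a carboxylic acid in place of the hydroxyl on the shared side chain would give.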